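The source may report more compounds than this note shows. Statements on the series, on what has been measured and on what is new or still open speak of the compounds shown alone.

Compound 3 `COc1ccc(F)cc1CNCCCNc1ccnc2cc(Cc3cc(C)cc(C)c3)ccc12` gives 940 nM in an ADME assay on HepG2 cells (Homo sapiens) for cytotoxicity, read by luminescence, CellTiter-Glo and ATP content, with a stated time of 72 h (a lower number here means that less compound is needed, a higher number that more compound is needed for the effect), the lowest of the three numbers in hand. Compound 1 `COc1ccc(F)cc1CNCCCNc1ccnc2cc(C3CCCCC3)ccc12` gives 2290 nM and compound 2 `COc1ccc(Oc2ccc3c(NCCCNCc4cc(F)ccc4OC)ccnc3c2)cc1` gives 7000 nM; the steps into compound 3 run a 2.4-fold lower number from compound 1 to compound 3 (0.39 log units; beyond the scatter) and a 7.4-fold lower number from compound 2 to compound 3 (0.87 log units; beyond the scatter), both modest. Compound 4 `COc1ccc(F)cc1CNCCCNc1ccnc2cc(-c3cccc4ccccc34)ccc12` differs from compound 3 by naphthalen-1-yl in place of 3,5-dimethylbenzyl on an aromatic carbon. Going by the values given here, no measured step places a fused two-ring group at this carbon, so the two steps into compound 3 only indicate how far the number at this position has moved so far. A step of comparable size is expected for a 1.7-fold higher number from compound 3 to compound 4 (0.23 log units; within the scatter), direction uncertain but leaning to a higher number, since compound 3 already holds the lowest value 940 nM. Compound 4 is expected at 1600 nM, within a range of 600 nM to 4500 nM.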

Compound 4, half-maximal effective concentration: 16000 nM
For compound 4 the middle estimate is 10-fold (1.00 log units) below the measured one; the whole stated range lies below it.
By their numbers in this assay, from the lowest: compound 3; then compound 1; then compound 2; then compound 4.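

Going by these compounds alone, at this aromatic carbon, naphthalen-1-yl gives the highest number of the four compounds in this assay, with a 17-fold higher number from compound 3 to compound 4 (1.23 log units; beyond the scatter) as the only large step so far. The fused two-ring group also stands above both remaining groups, with a 7.0-fold higher number from compound 1 to compound 4 (0.84 log units; beyond the scatter) and a 2.3-fold higher number from compound 2 to compound 4 (0.36 log units; beyond the scatter). Nothing available accounts for the size of these steps.

As far as these compounds go, whether naphthalen-2-yl at this carbon would give a similar number stays open. So does the effect of a piperidine or a carboxylic acid there.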